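The source may report more compounds than this note shows. Statements on the series, on what has been measured and on what is new or still open speak of the compounds shown alone.

In a functional assay on MCF7 cells (Homo sapiens) for antiproliferative activity, read by CCK-8 assay, with a stated time of 72 h (a higher number here means a weaker inhibitor, a lower number a stronger inhibitor), compound 2 `Cc1cccc(C(=O)Nc2cccc(-c3oc4cc(-c5ccc(F)cc5)ccc4c(=O)c3O)c2)c1` gives 7850 nM. Within the data shown here, that is the lowest of the two numbers recorded so far, but the only other compound, compound 1 `O=C(Nc1cccc(-c2oc3cc(-c4ccc(F)cc4)ccc3c(=O)c2O)c1)c1ccc(F)cc1`, gives 8590 nM in this assay, and the gap between them lies within the scatter, so no order between the two can be read from it. Among the measured compounds shown here, the single measured step that bears on the present question is a 1.1-fold lower number from compound 1 to compound 2 (0.04 log units; within the scatter), in which the aryl group on the carbonyl carbon was exchanged and the number hardly moved. Compound 3 `O=C(Nc1cccc(-c2oc3cc(-c4ccc(F)cc4)ccc3c(=O)c2O)c1)c1ccc([N+](=O)[O-])cc1` has not yet been measured. It differs from compound 2 as follows: 4-nitrophenyl in place of 3-methylphenyl on a carbonyl carbon. For the measured compounds named here, this is a change at the same place as the one measured step, and that step stayed within the scatter, so there is no precedent here for a large movement in either direction. The expected step is therefore a 1.0-fold higher number from compound 2 to compound 3 (0.01 log units; within the scatter), which is nothing beyond the scatter. Compound 3 is estimated at 8000 nM, with a range from 3500 nM to 18000 nM.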

Compound 3, half-maximal inhibitory concentration: 3970 nM
Compound 3: middle estimate off by 2.0-fold (0.30 log units), on the high side, within the range that was stated.
By their numbers in this assay, from the lowest: compounds 3, 2 and 1 (each within the scatter of the next, the first and the last beyond it).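

In this assay the aryl group on the carbonyl carbon produces its first step beyond the scatter, although a modest one, when nitro stands in place of fluoro on an aromatic carbon (a 2.2-fold lower number from compound 1 to compound 3 (0.34 log units; beyond the scatter)). Among these compounds, the exchange of 3-methylphenyl for 4-nitrophenyl at the same carbonyl carbon (a 2.0-fold lower number from compound 2 to compound 3 (0.30 log units; within the scatter)) remains within the scatter, so compound 3 cannot be ordered against compound 2, and only the pair of compound 1 and compound 3 shows that the number at this position can move measurably at all. No accompanying measurement bears on why the number shifted with this exchange of groups, and the step therefore stands without an explanation.

On these data alone, it remains open whether an amine or a carboxylic acid on the aromatic carbon that carries the nitro group in compound 3 would leave the number about where it is or move it further, and whether a longer chain in place of the aryl group on the carbonyl carbon would be accepted. As far as these compounds go, all three compounds share the same core, so how far the number depends on that core also remains open.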